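This account rests on a few compounds, and the source may have more. Where it says the series, first, only, none or still open, it means among the compounds named here.

Compound 1, `COc1nc(-c2ccccc2F)ccc1[C@@H](c1ccccc1)[C@@](O)(CCN(C)C)c1cccc2ccccc12`, is examined in a toxicity assay on Vero cells (Chlorocebus sabaeus) for cytotoxicity; a lower number here means that less compound is tolerated, a higher number that more compound is tolerated. In this assay compound 1 gives > 50 ug/mL, which is a limit of the assay rather than a number. Going by the values given here, its one measured neighbour, compound 2, `COc1nc(-c2ccc(Cl)c(F)c2)ccc1[C@@H](c1ccccc1)[C@@](O)(CCN(C)C)c1cccc2ccccc12`, carries 4-chloro-3-fluorophenyl in place of 2-fluorophenyl on an aromatic carbon. In this assay compound 2 gives > 50 ug/mL, again a limit of the assay. The step that the two limits leave unreadable from compound 1 to compound 2 therefore cannot be read, since both values sit at the limit of > 50 ug/mL in this assay, at which 2 of the 2 values shown sit. Among the compounds with values here, compound 1 thus stands only at a limit, with no measured step of known size around it.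

The unmeasured compound 3, `COc1nc(C2CCOCC2)ccc1[C@@H](c1ccccc1)[C@@](O)(CCN(C)C)c1cccc2ccccc12`, differs from compound 1 by oxan-4-yl in place of 2-fluorophenyl on an aromatic carbon. Within the data shown here, no readable measured step bears on this change; the only step available is the unreadable one just described. As every value shown rests at the limit, neither direction nor size can be drawn from the data, and the most that can be said is that the shared core has tolerated two aryl groups on that aromatic carbon up to the limit. Compound 3 is therefore expected to sit at or near the same limit, with an estimated step that the limit leaves unreadable from compound 1 to compound 3. Compound 3 is estimated at 60 ug/mL, within 30 ug/mL to 120 ug/mL.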

Compound 3, half-maximal cytotoxic concentration: > 50 ug/mL
Compound 3: a limit, no number (the forecaster's own chance of this, stated with the estimate: 75%); the middle value is on the limit's open side.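

Compound 3 also gives only a limit in this assay, so no new step can be read: the steps from compound 1 and compound 2 to compound 3 stay unreadable, and all three compounds rest at one value: the limit of > 50 ug/mL in this assay, at which 3 of the 3 values shown sit.

The compounds shown leave open how much of each compound the cells would tolerate past this limit, and whether the groups compared differ at all.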